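A few compounds are considered here, and "the series" means these few. Any claim that something is new, unique, unknown or untested is made for them only; others in the source may bear on it.

Measured compounds:

Compound 1 `CC(C)N(Cc1cccc(OCCCCCC(=O)O)c1)C(=O)c1ccc(-c2cccc(-c3ccccc3)c2)cc1` – in an ADME assay on HepG2 cells (Homo sapiens) for cytotoxicity, read by CellTiter-Glo and resazurin assay, with a stated time of 72 h (on this read-out higher numbers stand for an effect only at larger amounts of compound and lower numbers for an effect already at smaller amounts), compound 1 gives > 26000 nM, which is a limit of the assay rather than a number.
Compound 2 `CC(C)N(Cc1cccc(OCCCCCC(=O)O)c1)C(=O)c1ccc(-c2ccco2)cc1` – in this assay compound 2 gives > 26000 nM, again a limit of the assay.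
Compound 3 `CC(C)N(Cc1cccc(OCCCCCC(=O)O)c1)C(=O)c1ccc(-c2ccsc2)cc1` – in this assay compound 3 gives > 26000 nM, also a limit of the assay.

Compound 3 therefore stands where all three measured compounds stand, at the upper edge of what this assay can report; no compound in this set has shown a readable value, as noted in the limit of > 26000 nM in this assay, at which 3 of the 3 values shown sit. The steps between them are all unreadable: a step that the two limits leave unreadable from compound 1 to compound 2, a step that the two limits leave unreadable from compound 1 to compound 3 and a step that the two limits leave unreadable from compound 2 to compound 3. Compound 4 `CC(C)N(Cc1cccc(OCCCCCC(=O)O)c1)C(=O)c1ccc(-c2ccc3[nH]ccc3c2)cc1` differs from compound 3 in one place: 1H-indol-5-yl in place of thiophen-3-yl on an aromatic carbon. Every measured step bears on this change only insofar as exchanging the group on that aromatic carbon, whether for a biphenyl, a furan or a thiophene, has left the read-out at the limit each time. The expected step that the limit leaves unreadable from compound 3 to compound 4 is therefore none beyond the scatter, with the value most likely again a limit. Compound 4 is estimated at 40000 nM in this assay, with a range from 20000 nM to 100000 nM.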

Compound 4, half-maximal effective concentration: > 26000 nM
Compound 4: no number, only a limit (the forecaster's own chance of this, stated with the estimate: 85%); the middle value is on the limit's open side.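

Among these compounds, compound 4 also gives only a limit, so no step between it and compound 1, compound 2 or compound 3 can be read: the limit of > 26000 nM in this assay, at which 4 of the 4 values shown sit. The compounds shown leave open what value any of them would reach in this assay, and whether exchanging the group on that aromatic carbon changes it.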